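From Methoxycarbonyl to Ethoxycarbonyl

The source may hold more compounds than are shown below. What is called first, only, known or untested is meant among the compounds shown, and "the series" means these compounds.

In a functional assay on the whole organism for agonist activity, with Mus musculus as the target (a higher number here means that more compound is needed for the effect, a lower number that less compound is needed), compound 1 `CC(=O)N(C)CC#CCN1CCCC1` gives 0.3 mg/kg and compound 2 `COC(=O)N(C)CC#CCN1CCCC1` gives 1.4 mg/kg as the higher of the two numbers. The change to compound 3 `CCOC(=O)N(C)CC#CCN1CCCC1` is methyl in place of hydrogen on a saturated chain carbon bound to an oxygen next to a carbonyl group and reads methoxy to ethoxy. Going by the values given here, only one measured step bears on it (a 4.7-fold higher number from compound 1 to compound 2 (0.67 log units; beyond the scatter)), a modest one that put methoxy in place of methyl on a carbonyl carbon. That step did not alter this chain, so the guidance is weak, but a further modest rise in the number is expected. The estimated step is a 2.1-fold higher number from compound 2 to compound 3 (0.33 log units; beyond the scatter) and remains uncertain. Compound 3 is estimated at 3 mg/kg in this assay with an expected range of 1 mg/kg to 9 mg/kg around it.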

Compound 3, dose for half-maximal effect: 66 mg/kg
Estimate against measurement, compound 3: 22-fold (1.34 log units) below; the whole stated range lies below it.
By their numbers in this assay, from the lowest: compound 1; then compound 2; then compound 3.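

In this assay, one added methyl on the saturated chain carbon bound to an oxygen next to a carbonyl group has a large effect (a 47-fold higher number from compound 2 to compound 3 (1.67 log units; beyond the scatter)), so this part of the chain is far from indifferent to small changes. Ethoxy in place of methyl on the carbonyl carbon gives the widest step of the series (a 220-fold higher number from compound 1 to compound 3 (2.34 log units; beyond the scatter)). Nothing shown explains this sharp rise.

As far as these compounds go, whether a longer chain such as propoxy raises the number further remains open. So does how an amine on the carbonyl carbon would compare with methyl and the two alkoxy groups.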